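The source may report more compounds than this note shows. Statements on the series, on what has been measured and on what is new or still open speak of the compounds shown alone.

Measured so far in a functional assay on CHO cells for agonist activity at adenosine receptor A2b (Homo sapiens), read by AlphaScreen and cAMP accumulation; on this read-out higher numbers stand for an effect only at larger amounts of compound and lower numbers for an effect already at smaller amounts:
compound 1, `CCOc1ccc(-c2c(C#N)c(N)nc(SCc3ccn[nH]3)c2C#N)cc1`, gives 332 nM
compound 2, `N#Cc1c(N)nc(SCC(=O)NCO)c(C#N)c1-c1ccc(OCC2CC2)cc1`, gives 182 nM
compound 3, `CCOc1ccc(-c2c(C#N)c(N)nc(SCC(N)=O)c2C#N)cc1`, gives 38 nM

Among these three numbers compound 2 stands second highest. Its nearest neighbour is compound 1, whose number is within the scatter of that of compound 2, so no order between the two can be read. Compound 3 lies furthest from compound 2, with a number beyond the scatter below it.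

The new compound is compound 4, `CNC(=O)CSc1nc(N)c(C#N)c(-c2ccc(OCC3CC3)cc2)c1C#N`. It differs from compound 2 in one place: hydrogen in place of hydroxy on a saturated chain carbon bound to an amide-type nitrogen.

Going by the values given here, the only single-place step that has been measured is an 8.7-fold lower number from compound 1 to compound 3 (0.94 log units; beyond the scatter). That step alters the group on the saturated chain carbon bound to a sulfur, not the carbon bound to the amide-type nitrogen, so it does not bear directly on the change from compound 2 to compound 4. Among the compounds with values here, compound 2 and compound 3 differ in more than one place, and their two values show only that compound 3 sits lower. Within the data shown here, no measured step thus speaks to the loss of a hydroxy at this position, and the expectation rests on the change being a small one.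

The expected step is a 1.4-fold lower number from compound 2 to compound 4 (0.15 log units; within the scatter), a shift within or near the scatter. Compound 4 is therefore estimated at 130 nM, with a range from 45 nM to 380 nM.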

Compound 4, half-maximal effective concentration: 94 nM
Compound 4: the middle estimate sits 1.4-fold (0.14 log units) above what was measured, and the stated range covers the measured number.
By their numbers in this assay, from the lowest: compound 3; then compounds 4, 2 and 1 (each within the scatter of the next, the first and the last beyond it).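

In this assay, going by these compounds alone, the exchange of hydroxymethyl for methyl on the amide-type nitrogen gives a 1.9-fold lower number from compound 2 to compound 4 (0.29 log units; within the scatter), the first measured step at this position. With the shift inside the scatter, compound 2 and compound 4 cannot be told apart, so on this read-out the hydroxy on this saturated chain carbon can be lost without a change that can be read, at least on the core these two compounds share. Nothing at hand explains this result or tells what, if anything, the hydroxy does at this position.

The compounds shown leave open how much else this position accepts: whether a longer chain such as propyl, an amine or a carboxylic acid on the saturated chain carbon bound to an amide-type nitrogen would stay within the scatter of compound 4 or move beyond it. Within the data shown here, compound 3 and compound 4 differ in more than one place and no single step connects them, so what the methyl itself contributes also stays open.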